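Swapping the sulfonyl-bearing substituent on the alkyne-linked ring

The source may hold more compounds than are shown below. What is called first, only, known or untested is meant among the compounds shown, and "the series" means these compounds.

Three acids sharing one core have been tested. Compound 1 `CN(C)S(=O)(=O)c1ccc(F)c(C#Cc2cc(Cl)ccc2OCC(=O)O)c1` gives 3.1 nM in an assay on CHO cells for displacement of a labelled ligand from prostaglandin D2 receptor 2 (Homo sapiens), read by scintillation counting; on this read-out higher numbers stand for weaker inhibition and lower numbers for stronger inhibition. Compound 2 `CN(c1cccc(C#Cc2cc(Cl)ccc2OCC(=O)O)c1)S(C)(=O)=O` gives 122 nM in this assay, and compound 3 `CS(=O)(=O)Cc1cccc(C#Cc2cc(Cl)ccc2OCC(=O)O)c1` gives 48 nM in this assay, which places compound 3 second highest of the three numbers, with compound 2 nearest and compound 1 furthest. The next compound, compound 4 `CN(C)S(=O)(=O)c1cccc(C#Cc2cc(Cl)ccc2OCC(=O)O)c1`, is not yet measured. Against compound 3 the change is dimethylsulfamoyl in place of (methylsulfonyl)methyl on an aromatic carbon. Going by the values given here, only one step bears on it: a 2.5-fold lower number from compound 2 to compound 3 (0.41 log units; beyond the scatter). Compound 1, which also carries dimethylsulfamoyl, shows a far lower number than compound 3, though it differs in a second place as well. A lower number is therefore expected for compound 4, estimated at 10 nM (range 3 nM to 35 nM), a step of a 4.8-fold lower number from compound 3 to compound 4 (0.68 log units; beyond the scatter) from compound 3.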

Compound 4, inhibition constant: 14 nM
The estimate for compound 4 lay 1.4-fold (0.15 log units) below the measured number; measured number inside the range.
By their numbers in this assay, from the lowest: compound 1; then compound 4; then compound 3; then compound 2.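

Among the three groups placed on this aromatic carbon, dimethylsulfamoyl gives the lowest number, with a 3.4-fold lower number from compound 3 to compound 4 (0.54 log units; beyond the scatter) against (methylsulfonyl)methyl and an 8.7-fold lower number from compound 2 to compound 4 (0.94 log units; beyond the scatter) against methyl(methylsulfonyl)amino. The fluoro effect can now be read apart from the sulfonyl-bearing group, since a 4.5-fold higher number from compound 1 to compound 4 (0.65 log units; beyond the scatter) comes with hydrogen in place of fluoro alone. No measurement here accounts for either change.

From the compounds shown here alone, whether chloro or methoxy in place of that fluoro would also give a lower number remains open. So does the effect of replacing the dimethylamino part of the sulfamoyl group with a pyrrolidine or morpholine ring.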